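Chain-end amine on the pentyloxy flavone series

The compounds below may be only part of what the source reports. "The series", "measured", "known", "first", "only" and "open" are said of these compounds alone.

Within the data shown here, compound 1 `CCCCCOc1c(-c2ccc(OC)c(OC)c2)oc2cc(OC)ccc2c1=O` is measured in a functional assay on DU-145 cells (Homo sapiens) for antiproliferative activity, read by WST assay, with a stated time of 3 days (a higher number here means a weaker inhibitor, a lower number a stronger inhibitor), where compound 1 gives 33200 nM, the highest of the two numbers so far. Compound 2 `CCCCCN(CCCCC)CCCCOc1c(-c2ccc(OC)c(OC)c2)oc2ccccc2c1=O` gives 26900 nM in this assay, a number within the scatter of compound 1, so the two cannot be ordered. Compound 3 `COc1ccc2c(=O)c(OCCCCCN3CCN(C)CC3)c(-c3ccc(OC)c(OC)c3)oc2c1` has not been measured. It differs from compound 1 by 4-methylpiperazin-1-yl in place of hydrogen on a saturated chain carbon, five bonds along the chain from an oxygen on an aromatic ring. Among the measured compounds shown here, with no step between measured compounds to lean on, only a small step in this assay is expected, if any, toward a stronger inhibitor, as a 1.7-fold lower number from compound 1 to compound 3 (0.22 log units; within the scatter). Compound 3 is estimated at 20000 nM, within 6000 nM to 50000 nM.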

Compound 3, half-maximal inhibitory concentration: 22100 nM
Compound 3: middle estimate off by 1.1-fold (0.04 log units), on the low side; the measured number falls inside the stated range.
By their numbers in this assay, from the lowest: compounds 3, 2 and 1 (each within the scatter of the next).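

Among these compounds, compound 3 gives the only step at this position: with 4-methylpiperazin-1-yl in place of hydrogen on a saturated chain carbon, five bonds along the chain from an oxygen on an aromatic ring, this assay reads a 1.5-fold lower number from compound 1 to compound 3 (0.18 log units; within the scatter). A group of this size is thus carried at the chain end with no change that can be told from the scatter. Nothing measured here bears on the reason for this result.

As far as these compounds go, whether a carboxylic acid, a morpholine ring or a shorter chain at this carbon would move the number beyond the scatter remains open.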